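The source may report more compounds than this note shows. Statements on the series, on what has been measured and on what is new or still open speak of the compounds shown alone.

Measured compounds in this cytotoxicity series:

compound 1 `CN1CCC(NC(=O)c2ccc(Nc3ncc([N+](=O)[O-])c(NC4CCCC4)n3)cc2)CC1` — 5800 nM
compound 2 `CN1CCN(c2ccc(Nc3ncc(F)c(NC4CCCC4)n3)cc2)CC1` — 25000 nM
compound 3 `COc1cc(C(=O)NC2CCN(C)CC2)ccc1Nc1ncc(Br)c(NC2CCCC2)n1` — 4900 nM

In a functional assay on HepG2 cells (Homo sapiens) for cytotoxicity, read by MTT assay, with a stated time of 48 h (a lower number here means a stronger inhibitor, a higher number a weaker inhibitor), compound 3 gives 4900 nM. Compound 1 gives a number within the scatter of that, so the two cannot be told apart. Compound 2 gives a number beyond the scatter, higher than that of compound 3. For the measured compounds named here, the three differ in several places at once, so no single-point step between measured compounds is available.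

Compound 4 `COc1cc(C(=O)NC2CCN(C)CC2)ccc1Nc1ncc(Cl)c(NC2CCCC2)n1` differs from compound 3 in one place: chloro in place of bromo on an aromatic carbon. Going by the values given here, with no comparable step to lean on, the expectation is a small change, within the scatter, in no set direction. Compound 4 is expected to give 5000 nM, in a range from 2500 nM to 10000 nM. The step of a 1.0-fold higher number from compound 3 to compound 4 (0.01 log units; within the scatter) is expected to stay within the scatter.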

Compound 4, half-maximal inhibitory concentration: 9300 nM
The estimate for compound 4 lay 1.9-fold (0.27 log units) below the measured number, and the stated range covers the measured number.
By their numbers in this assay, from the lowest: compounds 3, 1 and 4 (each within the scatter of the next); then compound 2.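

In this assay, for the compounds shown here, the only single-place comparison is a 1.9-fold higher number from compound 3 to compound 4 (0.28 log units; within the scatter), which shows that chloro and bromo cannot be told apart at this position, on an aromatic carbon ortho to a cyclopentylamino group. Nothing measured here bears on this result. Compounds 1 and 2 carry other groups at this position but also differ elsewhere, so they say nothing about it on its own. As far as these compounds go, whether a methyl group, a nitrile or a plain hydrogen at this position would give a step beyond the scatter remains open.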